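This account rests on a few compounds, and the source may have more. Where it says the series, first, only, none or still open, it means among the compounds named here.

The study concerns a small set of compounds built on one shared core and tested in a functional assay on B16 cells (Mus musculus) for cytotoxicity, read by MTT assay, with a stated time of 48 h; on this read-out lower numbers stand for stronger inhibition and higher numbers for weaker inhibition. Compound 1 `OCCCn1cc(-c2ccc(C(F)(F)F)cc2)nn1` gives > 100000 nM in this assay, which is a limit of the assay and not a number. Compound 2 `COc1cccc(Cn2cc(-c3ccc(C)cc3)nn2)c1` gives 19500 nM in this assay. Compound 3 `CC1(C)OCC(Cn2cc(C(O)c3ccc(C(F)(F)F)cc3)nn2)O1` gives > 100000 nM in this assay, again a limit rather than a number. Compound 1 therefore stands at the limit of > 100000 nM in this assay, at which 2 of the 3 values shown sit, so that most of the set shows no measurable inhibition at the concentrations tested. Among the compounds with values here, no step between two measured compounds that differ in a single place is available here.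

Compound 4 `CC1(C)OC[C@H](Cn2cc(-c3ccc(C(F)(F)F)cc3)nn2)O1` has not yet been measured. It differs from compound 1 by 2,2-dimethyl-1,3-dioxolan-4-yl in place of 2-hydroxyethyl on a saturated chain carbon bound to an aromatic nitrogen. Compound 3 carries the same 2,2-dimethyl-1,3-dioxolan-4-yl group and sits at the limit, > 100000 nM. The expected step that the limit leaves unreadable from compound 1 to compound 4 is therefore none beyond the scatter. Compound 4 is expected to give about 120000 nM in this assay, with a range from 30000 nM to 500000 nM.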

Compound 4, half-maximal inhibitory concentration: > 100000 nM
Compound 4 was reported as a limit (the forecaster's own chance of this, stated with the estimate: 70%); the middle value does not contradict the limit.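

Compound 4 gives > 100000 nM in this assay, which is a limit and not a number. Compound 1 also stands at a limit, so no step can be read between compound 1 and compound 4: the limit of > 100000 nM in this assay, at which 3 of the 4 values shown sit. The compounds shown leave open how much inhibition compound 1 and compound 4 would show beyond that limit.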